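A few compounds are considered here, and "the series" means these few. Any claim that something is new, unique, unknown or untested is made for them only; others in the source may bear on it.

Compound 1 `N#Cc1ccn2c(-c3ccccc3)c(-c3ccccc3)c(Cc3ccccc3)c2c1`, tested in an assay for inhibition of Polyunsaturated fatty acid lipoxygenase ALOX15 (Oryctolagus cuniculus) (a higher number here means a weaker inhibitor, a lower number a stronger inhibitor), gives 46000 nM, which marks it as a weak inhibitor. Compound 2 `N#Cc1ccn2c(-c3ccccc3)c(-c3ccccc3)c(C(O)c3ccc(Cl)cc3)c2c1` carries a different group on the shared core, but in this assay compound 2 gives "not determined" (no result reported), so its standing cannot be placed. Compound 3 `N#Cc1ccn2c(-c3ccccc3)c(-c3ccccc3)c(C(=O)c3ccccc3)c2c1` differs from compound 2 by benzoyl in place of (4-chlorophenyl)(hydroxy)methyl on an aromatic carbon. For the measured compounds named here, with compound 2 unmeasured there is no step to compare against, and the only anchor is the weak result of compound 1; a change no larger than the usual scatter is expected, with no firm direction. Compound 3 is therefore estimated at 30000 nM in this assay, within 8000 nM to 100000 nM.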

Compound 3, half-maximal inhibitory concentration: 43000 nM
Beside the measured number, compound 3's estimate is 1.4-fold (0.16 log units) below it, and the stated range covers the measured number.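

In this assay, for the compounds shown here, the first pair that can be compared at this aromatic carbon shows a 1.1-fold lower number from compound 1 to compound 3 (0.03 log units; within the scatter) for benzoyl in place of benzyl. Adding the carbonyl to the link between the shared core and the phenyl ring therefore gives a reading that cannot be told apart from the original, and both compounds remain weak inhibitors. No supporting evidence is available to explain this result.

With no result for compound 2, the (4-chlorophenyl)(hydroxy)methyl group remains unread. On these data alone, it also remains open whether an amine, a carboxylic acid or a longer chain on this carbon would give a stronger inhibitor.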